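The source may hold more compounds than are shown below. What is called first, only, known or untested is meant among the compounds shown, and "the series" means these compounds.

Measured compounds in an ADME assay on Huh-5-2 cells (Homo sapiens) for cytotoxicity; a higher number here means that more compound is tolerated, a lower number that less compound is tolerated:

Compound 1 `NC(=O)c1nc(C#Cc2ccccc2)n(COCCO)n1`: in this assay compound 1 gives > 50 ug/mL, a limit of the assay and not a number.
Compound 2 `COc1ccc(C#Cc2nc(C(N)=O)nn2COCCO)cc1`: in this assay compound 2 gives > 50 ug/mL, again a limit.
Compound 3 `Cc1ccc(C#Cc2nc(C(N)=O)nn2COCCO)cc1`: in this assay compound 3 gives > 50 ug/mL, also a limit.

All three sit at the same limit (the limit of > 50 ug/mL in this assay, at which 3 of the 3 values shown sit), so compound 3 stands level with the rest and nothing orders them. The steps among them, a step that the two limits leave unreadable from compound 1 to compound 2, a step that the two limits leave unreadable from compound 1 to compound 3 and a step that the two limits leave unreadable from compound 2 to compound 3, are unreadable for the same reason: two limits give no size and no direction.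

Compound 4 `CCCCCc1ccc(C#Cc2nc(C(N)=O)nn2COCCO)cc1` differs from compound 3 by butyl in place of hydrogen on a saturated chain carbon bound to an aromatic carbon. Going by the values given here, no measured step bears on this change in a readable way; the substituents tried so far on that aromatic carbon (hydrogen, methoxy, methyl) all left the readout at the limit. The expected step of a number no higher from compound 3 to compound 4 (the limit leaves the size open) is therefore set near zero, with a wider range on the lower side to allow that the longer chain may bring the readout into the measurable window. Compound 4 is expected at 50 ug/mL, with a range from 15 ug/mL to 120 ug/mL, and most likely again reported only as a limit.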

Compound 4, half-maximal cytotoxic concentration: 25 ug/mL
Estimate against measurement, compound 4: 2.0-fold (0.30 log units) above; the range from low to high includes it.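

In this assay compound 4 gives 25 ug/mL, the only number among the compounds shown and not a limit of the assay. Butyl in place of hydrogen on a saturated chain carbon bound to an aromatic carbon gives an at least 2.0-fold lower number from compound 3 to compound 4 (0.30 log units; that floor lies within the scatter), while the comparisons with the other two compounds give an at least 2.0-fold lower number from compound 2 to compound 4 (0.30 log units; that floor lies within the scatter) and an at least 2.0-fold lower number from compound 1 to compound 4 (0.30 log units; that floor lies within the scatter); each is only a floor, so the full size of the change stays open. The steps among compound 1, compound 2 and compound 3 cannot be read, and only compound 4 gives this position a number: the limit of > 50 ug/mL in this assay, at which 3 of the 4 values shown sit.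

From the compounds shown here alone, whether an ethyl or propyl group, or a chain longer than pentyl, would shift the number remains open, and a single number sets no trend with chain length. Also open, going by these compounds, is how an amine or a carboxylic acid at the end of the chain would read in this assay.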